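The source may report more compounds than this note shows. Statements on the series, on what has been measured and on what is new or still open speak of the compounds shown alone.

Compounds measured so far in a functional assay on HepG2 cells (Homo sapiens) for antiproliferative activity, read by spectrophotometry, with a stated time of 2 days; a higher number here means a weaker inhibitor of growth, a lower number a stronger inhibitor of growth:

- compound 1, `CN(c1cccc2c1CN(c1nc(Nc3ccc(Cl)c(C(F)(F)F)c3)ncc1C(F)(F)F)C2)S(C)(=O)=O`: 16000 nM
- compound 2, `COc1ccc(C(F)(F)F)cc1Nc1ncc(C(F)(F)F)c(N2Cc3cccc(N(C)S(C)(=O)=O)c3C2)n1`: > 30000 nM, a limit only

Compound 2 stands at a limit in this assay: its reading, > 30000 nM, is a limit of the assay and not a number (the limit of > 30000 nM in this assay, at which 1 of the 2 values shown sits). Among the measured compounds shown here, the single measured step at this position, an at least 1.8-fold higher number from compound 1 to compound 2 (0.27 log units; that floor lies within the scatter), ends at that limit, and its floor lies within the usual scatter.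

Compound 3, `Cc1ccc(Nc2ncc(C(F)(F)F)c(N3Cc4cccc(N(C)S(C)(=O)=O)c4C3)n2)c(C)c1`, changes the same position: 2,4-dimethylphenyl in place of 2-methoxy-5-(trifluoromethyl)phenyl on a nitrogen on an aromatic ring. For the measured compounds named here, the only measured step that bears on this position is the one just given; it was small at its floor and gave no number at its end. Going by the values given here, no step compares a dimethylphenyl with either of the measured aryl groups. The step from compound 2 to compound 3 is therefore expected to be small: a number no higher from compound 2 to compound 3 (the limit leaves the size open), none beyond the scatter. Compound 3 is expected to give about 30000 nM, in the range 10000 nM to 90000 nM.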

Compound 3, concentration for 50% growth inhibition: 19100 nM
Compound 3: the middle estimate sits 1.6-fold (0.20 log units) above what was measured; the range from low to high includes it.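

In this assay, the 2,4-dimethylphenyl group gives a second measured number at this position, and it can be set against compound 1: a 1.2-fold higher number from compound 1 to compound 3 (0.08 log units; within the scatter). An aryl group of carbon only therefore cannot be told apart from 4-chloro-3-(trifluoromethyl)phenyl here, so these two compounds show no need for the chlorine or the trifluoromethyl group at this reading. The other step, an at least 1.5-fold lower number from compound 2 to compound 3 (0.19 log units; that floor lies within the scatter), does not separate the 2,4-dimethylphenyl and 2-methoxy-5-(trifluoromethyl)phenyl groups, and its full size stays unknown because compound 2 gives only a limit: the limit of > 30000 nM in this assay, at which 1 of the 3 values shown sits.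

Still open, on these data alone, is whether any group on this nitrogen moves the number beyond the scatter. An aryl ring carrying a primary amine or a carboxylic acid, or a pyridine ring in place of the phenyl ring, would test this.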